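The source may report more compounds than this note shows. Statements on the series, on what has been measured and on what is new or still open speak of the compounds shown alone.

Among the compounds with values here, in a functional assay on L1210 cells (Mus musculus) for inhibition (a lower number here means a stronger inhibitor, a higher number a weaker inhibitor), three compounds sharing one core have numbers so far. Compound 1 `COC(=O)C(CC(C)C)NC(=O)C(CC(C)C)Nc1ncnc2c1C(=O)C(OC)=CC2=O` gives 1300 nM, compound 2 `COC(=O)CNc1ncnc2c1C(=O)C(OC)=CC2=O` gives 4260 nM, and compound 3 `CCN(CC)CCNc1ncnc2c1C(=O)C(OC)=CC2=O` gives 898 nM. Compound 3 and compound 1 lie within the scatter of each other, so this assay cannot separate them, while compound 2 lies beyond the scatter from compound 3.

Compound 4 `COC1=CC(=O)c2ncnc(NCCN(C)C)c2C1=O` differs from compound 3 in one place, on a saturated chain carbon, two bonds along the chain from a nitrogen on an aromatic ring: dimethylamino in place of diethylamino on a saturated chain carbon, two bonds along the chain from a nitrogen on an aromatic ring. Within the data shown here, only one measured step touches this place, a 4.7-fold lower number from compound 2 to compound 3 (0.68 log units; beyond the scatter). That modest step swapped methoxycarbonyl for (diethylamino)methyl, whereas compound 4 keeps an amino group at the chain end and only exchanges diethylamino for dimethylamino. Among the measured compounds shown here, no measured pair shows that exchange directly, so the expectation is for no clear change. The expected step, a 1.1-fold higher number from compound 3 to compound 4 (0.05 log units; within the scatter), stays within the scatter. Compound 4 is estimated at 1000 nM, with an expected range from 450 nM to 2200 nM.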

Compound 4, half-maximal inhibitory concentration: 1140 nM
Compound 4: middle estimate off by 1.1-fold (0.06 log units), on the low side; low and high end bracket the measured number.
By their numbers in this assay, from the lowest: compounds 3, 4 and 1 (each within the scatter of the next); then compound 2.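

In this assay, the result is a 1.3-fold higher number from compound 3 to compound 4 (0.10 log units; within the scatter), so at this position the smaller dimethylamino group can stand in for diethylamino with no difference this assay can detect. The gain over the ester is also not tied to diethylamino alone, since replacing methoxycarbonyl with (dimethylamino)methyl gives a 3.7-fold lower number from compound 2 to compound 4 (0.57 log units; beyond the scatter) and the two amine-ended chains both sit apart from compound 2. Nothing available explains these numbers.

The compounds shown leave open how a primary amine or a ring amine such as piperidine or morpholine would behave at the chain end. They also leave open what a longer chain carrying the same dimethylamino group would do to the number.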